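This account rests on a few compounds, and the source may have more. Where it says the series, first, only, none or still open, it means among the compounds named here.

Compound 2, `COC(=O)N[C@@H](C[S+]([O-])Cc1ccccc1)C(=O)N1CCC[C@H]1c1ncc(-c2ccc(-c3ccc(-c4cnc([C@@H]5CCCN5C(=O)[C@@H](NC(=O)OC)C(C)C)[nH]4)cc3)cc2)[nH]1`, gives 11000 nM in an ADME assay on CCRF-CEM cells (Homo sapiens) for cytotoxicity; a higher number here means that more compound is tolerated, a lower number that less compound is tolerated. Its nearest measured neighbour is compound 1, `COC(=O)N[C@@H](CSC)C(=O)N1CCC[C@H]1c1ncc(-c2ccc(-c3ccc(-c4cnc([C@@H]5CCCN5C(=O)[C@@H](NC(=O)OC)C(C)C)[nH]4)cc3)cc2)[nH]1`, which in this assay gives 11000 nM. The step from compound 1 to compound 2 reads no change at the digits printed from compound 1 to compound 2 (within the scatter), so the two compounds stand level at the digits shown and neither can be ranked against the other.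

Compound 3, `COC(=O)N[C@@H](CS(=O)(=O)Cc1ccccc1)C(=O)N1CCC[C@H]1c1ncc(-c2ccc(-c3ccc(-c4cnc([C@@H]5CCCN5C(=O)[C@@H](NC(=O)OC)C(C)C)[nH]4)cc3)cc2)[nH]1`, is the next point in the series. Relative to compound 2 the change is a group of 10 heavy atoms (7 carbon, 2 oxygen, 1 sulfur; one six-membered aromatic ring of carbon only) in place of a group of 9 heavy atoms (7 carbon, 1 oxygen, 1 sulfur; one six-membered aromatic ring of carbon only), on a saturated chain carbon, two bonds along the chain from an amide-type nitrogen and a carbonyl carbon. For the measured compounds named here, only one measured step bears on this position, the one from compound 1 to compound 2, no change at the digits printed from compound 1 to compound 2 (within the scatter), in which a larger exchange at the same saturated chain carbon left the read-out where it was. Going by the values given here, the exchange now in hand is smaller and keeps the aromatic ring and the sulfur, so nothing among the measured compounds points to a shift in either direction. For compound 3 the expected step is therefore no change at the digits printed from compound 2 to compound 3 (within the scatter), none beyond the scatter. Compound 3 is accordingly estimated at 11000 nM in this assay, with a range from 5500 nM to 22000 nM.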

Compound 3, half-maximal cytotoxic concentration: > 100000 nM
Compound 3 ended at the assay's limit; the forecaster's own chance of this, stated with the estimate: 10%; middle value at least 9.0-fold (0.95 log units) from the limit.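

At this saturated chain carbon, two bonds along the chain from an amide-type nitrogen and a carbonyl carbon, this assay now shows a response to the substituent: an at least 9.0-fold higher number from compound 2 to compound 3 (0.95 log units; beyond the scatter), for a change that keeps the aromatic ring and the sulfur and adds one oxygen. Against the methylsulfanyl group the picture is the same, an at least 9.0-fold higher number from compound 1 to compound 3 (0.95 log units; beyond the scatter), whereas no change at the digits printed from compound 1 to compound 2 (within the scatter), so the benzyl group present in compound 2 is not enough on its own to move the read-out, and the difference between compound 2 and benzylsulfonyl in compound 3 is what goes with the step. The value of compound 3, > 100000 nM, is a limit of the assay and not a number: the limit of > 100000 nM in this assay, at which 1 of the 3 values shown sits.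

Open, from the compounds shown here alone, is whether the step needs the sulfonyl together with the benzyl group or the sulfonyl alone; a methylsulfonyl group on the same carbon would separate the two. Also open, going by these compounds, is whether other groups at this carbon, such as a sulfonamide or a carboxylic acid, would give a read-out like that of compound 3 or stay level with compound 1 and compound 2.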